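The compounds below may be only part of what the source reports. "The series", "measured", "known", "first", "only" and "open" are said of these compounds alone.

Values in a functional assay on HEY cells (Homo sapiens) for cytotoxicity, read by MTT assay, with a stated time of 72 h; on this read-out higher numbers stand for weaker inhibition and lower numbers for stronger inhibition:
- compound 1 `N[C@H]1CC[C@H](Nc2c(C(=O)NCc3ccc(F)cc3)nc(Br)c3cccnc23)CC1`: "not determined" (no result reported)
- compound 2 `COc1ccc(CNC(=O)c2nc(Br)c3cccnc3c2N[C@H]2CC[C@H](N)CC2)cc1`: 4000 nM
- compound 3 `C[C@H](NC(=O)c1nc(Br)c2cccnc2c1N[C@H]1CC[C@H](N)CC1)c1ccc(F)cc1`: > 10000 nM

Compound 3 gives > 10000 nM, which is a limit of the assay and not a number. Its true position is therefore open, and compound 1 offers no comparison.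

The next compound to be read is compound 4 `N[C@H]1CC[C@H](Nc2c(C(=O)NCc3ccccn3)nc(Br)c3cccnc23)CC1`, which differs from compound 3 as follows: (pyridin-2-yl)methyl in place of 1-(4-fluorophenyl)ethyl on an amide-type nitrogen. The change lies on an amide-type nitrogen, where (pyridin-2-yl)methyl takes the place of 1-(4-fluorophenyl)ethyl.

Within the data shown here, only one measured step bears on this nitrogen: an at least 2.5-fold higher number from compound 2 to compound 3 (0.39 log units; beyond the scatter), with 1-(4-fluorophenyl)ethyl in place of 4-methoxybenzyl. That step is modest and lies beyond the scatter, but it is a single step whose size is bounded by a limit. Removing 1-(4-fluorophenyl)ethyl is therefore expected to lower the number, returning it towards compound 2 at 4000 nM.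

The expected change is an at least 1.6-fold lower number from compound 3 to compound 4 (0.22 log units; that floor lies within the scatter). For compound 4 the estimated value is 6000 nM, with an expected range from 2000 nM to 15000 nM.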

Compound 4, half-maximal inhibitory concentration: > 20000 nM
Compound 4: no number, only a limit; the forecaster's own chance of this, stated with the estimate: 35%; middle value at least 3.3-fold (0.52 log units) from the limit.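

In this assay compound 4 gives > 20000 nM, a limit of the assay and not a number. Pyridin-2-yl in place of 4-methoxyphenyl on the saturated chain carbon bound to the amide-type nitrogen gives an at least 5.0-fold higher number from compound 2 to compound 4 (0.69 log units; beyond the scatter), so this is a second replacement of 4-methoxybenzyl at this nitrogen that raises the number, and among the compounds with a result none goes against this. The step between compound 3 and compound 4 cannot be read, because both ends are limits: the limit of > 10000 nM in this assay, at which 1 of the 4 values shown sits; the limit of > 20000 nM in this assay, at which 1 of the 4 values shown sits.

With no result for compound 1, the contribution of the methyl in 1-(4-fluorophenyl)ethyl cannot be separated from that of the fluorine. On these data alone, whether a longer chain on this nitrogen, or an amine or a carboxylic acid on its ring, would bring the number below that of compound 2 remains open.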